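Cyclopropyl in place of 4-fluorophenyl: expectation for compound 4

A few compounds are considered here, and "the series" means these few. Any claim that something is new, unique, unknown or untested is made for them only; others in the source may bear on it.

The series shares one core and varies the group on the five-membered aromatic ring with 3 nitrogen. Compound 1 `CCCCCCCc1cn(C(c2ccccc2)c2cc3cc(Br)ccc3nc2OC)nn1` carries heptyl there, compound 2 `COc1nc2ccc(Br)cc2cc1C(c1ccccc1)n1cc(-c2ccccc2)nn1` phenyl, compound 3 `COc1nc2ccc(Br)cc2cc1C(c1ccccc1)n1cc(-c2ccc(F)cc2)nn1` 4-fluorophenyl. In an ADME assay on PANC-1 cells (Homo sapiens) for cytotoxicity, read by sulforhodamine B assay, with a stated time of 48 h, tested at 10 uM (a lower number here means less inhibition, a higher number more inhibition at the concentration tested (going by the name of the read-out)), compound 1 gives 16.6%, compound 2 gives 30.1% and compound 3 gives 14.9%. Compound 3 sits at the low end of the three numbers: one of its two steps is a number 15.2 percentage points lower from compound 2 to compound 3 (beyond the scatter), whereas the other is a number 1.7 percentage points lower from compound 1 to compound 3 (within the scatter), so compounds 1 and 3 cannot be ordered. Among the measured compounds shown here, the only step beyond the scatter that starts from compound 1 is a number 13.5 percentage points higher from compound 1 to compound 2 (beyond the scatter).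

Compound 4 `COc1nc2ccc(Br)cc2cc1C(c1ccccc1)n1cc(C2CC2)nn1` differs from compound 3 by cyclopropyl in place of 4-fluorophenyl on an aromatic carbon. For the measured compounds named here, no measured step puts cyclopropyl at this position. The nearest guide is that a chain (heptyl, compound 1) and the fluorinated aryl (compound 3) give numbers within the scatter of each other, while plain phenyl (compound 2) stands apart. A small saturated ring is expected to behave like the chain, so no step beyond the scatter is expected, a number 1.1 percentage points higher from compound 3 to compound 4 (within the scatter). Compound 4 is estimated at 16%, within 4% to 30%.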

Compound 4, a percentage reported as inhibition, at one concentration (the size of the read-out at that concentration, not a potency): 21.8%
Compound 4: the middle estimate sits 5.8 percentage points below what was measured, within the range that was stated.
By their numbers in this assay, from the lowest: compounds 3, 1, 4 and 2 (each within the scatter of the next, the first and the last beyond it).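

In this assay the cyclopropyl group of compound 4 cannot be separated from any of the three earlier groups, with a number 6.9 percentage points higher from compound 3 to compound 4 (within the scatter) and a number 8.3 percentage points lower from compound 2 to compound 4 (within the scatter) and also a number 5.2 percentage points higher from compound 1 to compound 4 (within the scatter) at this position. Among the compounds shown here, the only steps beyond the scatter among the four compounds therefore remain those that reach compound 2 from compound 1 and compound 3, and neither the count of heavy atoms nor an aromatic against a non-aromatic ring sorts the four numbers. Nothing available bears on the reason for these numbers.

Open, on these data alone, is whether an amine or a carboxylic acid on this carbon would give a number beyond the scatter from compound 4. Also open, as far as these compounds go, is whether a propyl chain would stand with compound 1, and whether chloro in place of fluoro on the phenyl would stand with compound 3.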